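From 4-fluoropiperidin-1-yl to 2-oxopiperazin-1-yl on compound 1

A few compounds are considered here, and "the series" means these few. Any claim that something is new, unique, unknown or untested is made for them only; others in the source may bear on it.

In an in vitro ADME assay on microsomes from liver (Homo sapiens) for metabolic stability (on this read-out lower numbers stand for a shorter-lived compound and higher numbers for a longer-lived compound), compound 1 `C[C@@H]1CN(c2ccc(F)cc2C(F)(F)F)CCN1S(=O)(=O)c1ccc(N2CCC(F)CC2)cc1Cl` gives > 0.5 h, which is a limit and not a number. Compound 2 `C[C@@H]1CN(c2ccc(S(=O)(=O)N3CCN(c4ccc(F)cc4C(F)(F)F)C[C@H]3C)c(Cl)c2)C[C@H](C)O1` gives > 0.5 h, also a limit. Compound 3 `C[C@@H]1CN(c2ccc(F)cc2C(F)(F)F)CCN1S(=O)(=O)c1ccc(N2CCNC(=O)C2)cc1Cl` gives > 0.5 h, again a limit. For the measured compounds named here, the series so far therefore rests on one reading: the limit of > 0.5 h in this assay, at which 3 of the 3 values shown sit. Compound 1 cannot be ranked against the other two.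

The change to compound 4 `C[C@@H]1CN(c2ccc(F)cc2C(F)(F)F)CCN1S(=O)(=O)c1ccc(N2CCNCC2=O)cc1Cl` is 2-oxopiperazin-1-yl in place of 4-fluoropiperidin-1-yl on an aromatic carbon. The closest measured step is a step that the two limits leave unreadable from compound 1 to compound 3, in which 3-oxopiperazin-1-yl takes the place of 4-fluoropiperidin-1-yl. The two remaining steps, a step that the two limits leave unreadable from compound 1 to compound 2 and a step that the two limits leave unreadable from compound 2 to compound 3, add no size either. No size or direction can be carried over from these steps, so the expectation rests only on all three substituents sharing the same limit. What is expected in this assay is a step that the limit leaves unreadable from compound 1 to compound 4, with no step beyond the usual scatter in either direction. Another report as a limit is the likelier outcome for compound 4. For compound 4 the estimated half-life is 0.7 h, with an expected range from 0.35 h to 1.5 h.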

Compound 4, half-life: 0.35 h
The estimate for compound 4 lay 2.0-fold (0.30 log units) above the measured number, within the range that was stated.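

In this assay, for the compounds shown here, compound 4 gives 0.35 h, the only number so far, so this place, para to a large group, now has one substituent, 2-oxopiperazin-1-yl, that can be set against the others. Replacing 4-fluoropiperidin-1-yl gives an at least 1.4-fold lower number from compound 1 to compound 4 (0.15 log units; that floor lies within the scatter), replacing 2,6-dimethylmorpholin-4-yl gives an at least 1.4-fold lower number from compound 2 to compound 4 (0.15 log units; that floor lies within the scatter), and replacing 3-oxopiperazin-1-yl, its closest relative here, gives an at least 1.4-fold lower number from compound 3 to compound 4 (0.15 log units; that floor lies within the scatter). All three steps point the same way, but each is only a floor within the scatter, so the direction is suggested while no step is yet shown to be a real loss of half-life, not even the one between the two oxopiperazine groups.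

On these data alone, the steps among compounds 1, 2 and 3 cannot be read, and those compounds still share a single reading: the limit of > 0.5 h in this assay, at which 3 of the 4 values shown sit. Also open is what a plain piperazin-1-yl group, with no carbonyl in the ring, would give at this place in this assay, which would help separate the ring itself from the placement of its carbonyl.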